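The source may report more compounds than this note shows. Statements on the series, on what has been measured and on what is new or still open speak of the compounds shown alone.

Measured so far: compound 1 `CC(C)=CCC/C(C)=C/C[C@]12C[C@@H](CC=C(C)C)C(C)(C)[C@](CC=C(C)C)(C(=O)C(C(=O)c3ccc(O)c(O)c3)=C1O)C2=O` gives 11.7 ug/mL in a functional assay on HeLa cells (Homo sapiens) for inhibition; on this read-out higher numbers stand for weaker inhibition and lower numbers for stronger inhibition; compound 2 `CC(C)=CCC/C(C)=C/C[C@]12C[C@@H](CC=C(C)C)C(C)(C)[C@](CC=C(C)C)(C(=O)CC1=O)C2=O` gives 6.64 ug/mL. Compound 3 `CC(C)=CCC/C(C)=C/C[C@]12C[C@@H](CC=C(C)C)C(C)(C)[C@](C/C=C(\C)CCC=C(C)C)(C(=O)C(C(=O)c3ccc(O)c(O)c3)=C1O)C2=O` reaches only a limit of this assay, > 20 ug/mL.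

Compound 3 differs from compound 1 by 3-methylbut-2-en-1-yl in place of hydrogen on a saturated chain carbon bound to a double-bonded chain carbon. The resulting step, an at least 1.7-fold higher number from compound 1 to compound 3 (0.23 log units; that floor lies within the scatter), is known only as a floor because the limit of > 20 ug/mL in this assay, at which 1 of the 3 values shown sits, is where one of the three values sits. The difference between the core of compound 1 and that of compound 2 is not broken down here. Compound 4 `CC(C)=CCC/C(C)=C/C[C@]12C[C@@H](CC=C(C)C)C(C)(C)[C@](C/C=C(\C)CCC=C(C)C)(C(=O)CC1=O)C2=O` carries the same change on the core of compound 2: 3-methylbut-2-en-1-yl in place of hydrogen on a saturated chain carbon bound to a double-bonded chain carbon. The step from compound 2 onward is expected to be a 2.3-fold higher number from compound 2 to compound 4 (0.35 log units; beyond the scatter), set beside the measured one and resting on an at least 1.7-fold higher number from compound 1 to compound 3 (0.23 log units; that floor lies within the scatter). Compound 4 is therefore estimated at 15 ug/mL, with a fair chance that this assay reports only a limit.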

Compound 4, half-maximal inhibitory concentration: > 20 ug/mL
Compound 4: a limit, no number; the forecaster's own chance of this, stated with the estimate: 35%; middle value at least 1.3-fold (0.12 log units) from the limit.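

In this assay, compound 4 gives only a limit, > 20 ug/mL, and not a number. Putting 3-methylbut-2-en-1-yl in place of hydrogen on the core of compound 2 gives an at least 3.0-fold higher number from compound 2 to compound 4 (0.47 log units; beyond the scatter), which means weaker inhibition on this core. This does not show that the change has the same effect on both cores, as the step on the core of compound 1 has a floor within the scatter and the two steps cannot be compared in size: the same change on two cores in this assay, an at least 1.7-fold higher number (0.23 log units; that floor lies within the scatter) from compound 1 to compound 3 and an at least 3.0-fold higher number (0.47 log units; beyond the scatter) from compound 2 to compound 4; the limit leaves it open whether they differ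

The compounds shown leave open how far each step really reaches, since both end at a limit. They also leave open what a methyl group, or a shorter chain ending in an amine or a carboxylic acid, would do at this place.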